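A few compounds are considered here, and "the series" means these few. Any claim that something is new, unique, unknown or untested is made for them only; others in the source may bear on it.

Working notes on the series.

Compound 3 `O=C1NC(=O)/C(=C\c2ccc(OCC(=O)N3N=C(c4ccc(F)cc4)CC3c3ccccc3)cc2)S1` is the starting point for the next change. In an assay on cells for inhibition of histone deacetylase 8 (Homo sapiens), read by fluorescence, with a stated time of 30 min (a higher number here means a weaker inhibitor, a lower number a stronger inhibitor), compound 3 gives only a limit of the assay, > 50000 nM, the limit described by the limit of > 50000 nM in this assay, at which 1 of the 3 values shown sits. Compound 1 `O=C1NC(=O)/C(=C\c2ccc(OCC(=O)N3N=C(c4ccccc4)CC3c3ccc(C(F)(F)F)cc3)cc2)S1` gives 16000 nM, and compound 2 `O=C1NC(=O)/C(=C\c2ccc(OCC(=O)N3N=C(c4ccccc4)CC3c3ccc(F)cc3)cc2)S1` gives 26000 nM; the change from compound 1 to compound 2, fluoro in place of trifluoromethyl on an aromatic carbon, is a 1.6-fold higher number from compound 1 to compound 2 (0.21 log units; within the scatter).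

Compound 4 `O=C1NC(=O)/C(=C\c2ccc(OCC(=O)N3N=C(c4ccc(F)cc4)CC3c3ccc(F)cc3F)cc2)S1` differs from compound 3 by 2,4-difluorophenyl in place of phenyl on a saturated ring carbon. For the measured compounds named here, the only measured step that bears on it, the change from compound 1 to compound 2, also varied the fluorine pattern of the aryl on the saturated ring carbon and stayed within scatter. Compound 4 is therefore expected to stay near the limit, with an estimated 50000 nM (range 20000 nM to 150000 nM), a step of a number no higher from compound 3 to compound 4 (the limit leaves the size open).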

Compound 4, half-maximal inhibitory concentration: > 50000 nM
Compound 4 ended at the assay's limit; the forecaster's own chance of this, stated with the estimate: 60%; the middle value lies on the limit itself.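

In this assay no step can be read from compound 3 to compound 4, since both stand at a limit of the assay: the limit of > 50000 nM in this assay, at which 2 of the 4 values shown sit.

The compounds shown leave open whether 2,4-difluorophenyl in place of phenyl changes inhibition at all.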